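This account rests on a few compounds, and the source may have more. Where it says the series, first, only, none or still open, it means among the compounds named here.

Among the measured compounds shown here, compound 2 `COc1cccc(N2CCN(Cc3nc4ccccc4[nH]3)CC2)c1` gives the lowest of the two numbers so far in an assay on isolated protein for binding affinity to D(4) dopamine receptor (Homo sapiens) (on this read-out lower numbers stand for stronger inhibition and higher numbers for weaker inhibition), at 26.5 nM. Compound 1 `c1cncc(N2CCN(Cc3nc4ccccc4[nH]3)CC2)c1` gives 376 nM in this assay, and the step of a 14-fold lower number from compound 1 to compound 2 (1.15 log units; beyond the scatter) is the only one measured. Compound 3 `COc1ccc(N2CCN(Cc3nc4ccccc4[nH]3)CC2)cc1` differs from compound 2 by 4-methoxyphenyl in place of 3-methoxyphenyl on an amine nitrogen in a ring. That measured step exchanges a different ring and does not bear on swapping one methoxyphenyl for the other, so the direction is uncertain; a modest step, possibly toward weaker binding than compound 2, is expected. Compound 3 is estimated to give 70 nM in this assay, within 20 nM to 250 nM, an expected step of a 2.6-fold higher number from compound 2 to compound 3 (0.42 log units; beyond the scatter).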

Compound 3, inhibition constant: 20.4 nM
Beside the measured number, compound 3's estimate is 3.4-fold (0.54 log units) above it; low and high end bracket the measured number.
By their numbers in this assay, from the lowest: compounds 3 and 2 (each within the scatter of the next); then compound 1.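

In this assay, the 4-methoxyphenyl and 3-methoxyphenyl groups on this amine nitrogen in a ring cannot be told apart, since the step is a 1.3-fold lower number from compound 2 to compound 3 (0.11 log units; within the scatter). For these two compounds, then, the place of the methoxy group on the phenyl ring makes no measurable difference. The large gap from pyridin-3-yl also appears with the 4-methoxyphenyl group, as an 18-fold lower number from compound 1 to compound 3 (1.27 log units; beyond the scatter). No measurement here explains these numbers. Still open, as far as these compounds go, is whether the methoxy group itself matters, which plain phenyl, or phenyl carrying ethoxy or chlorine instead, could test.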